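Replacing dimethylamino with methoxy in a growth-inhibition series

A few compounds are considered here, and "the series" means these few. Any claim that something is new, unique, unknown or untested is made for them only; others in the source may bear on it.

Compound 1 `CN(C)c1ccc(NS(=O)(=O)c2c(F)c(F)c(F)c(F)c2F)cc1`: 417 nM
Compound 2 `O=S(=O)(Nc1ccc2c(c1)OCCO2)c1c(F)c(F)c(F)c(F)c1F`: 63 nM

Both values come from a functional assay on CAKI-1 cells (Homo sapiens) for inhibition; on this read-out lower numbers stand for stronger inhibition of growth and higher numbers for weaker inhibition of growth. Compound 1 has the higher of the two numbers. The gap between compound 1 and compound 2 lies beyond the usual scatter of such measurements. Compound 3 `COc1ccc(NS(=O)(=O)c2c(F)c(F)c(F)c(F)c2F)cc1` has not yet been measured in this assay. It differs from compound 1 in one place, with methoxy in place of dimethylamino on an aromatic carbon, para to a large group (methoxy in place of dimethylamino on an aromatic carbon).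

Among the compounds with values here, no measured pair in this small set isolates a change of this kind, so the size of the step has no direct precedent. Within the data shown here, the only guide is compound 2, which carries no dimethylamino group and gives 63 nM. A moderate step towards stronger inhibition of growth is therefore expected, although a result within the scatter of compound 1 cannot be ruled out. The expected step is a 2.8-fold lower number from compound 1 to compound 3 (0.44 log units; beyond the scatter). For compound 3 the estimated value is 150 nM, with an expected range from 50 nM to 450 nM.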

Compound 3, concentration for 50% growth inhibition: 56 nM
Estimate against measurement, compound 3: 2.7-fold (0.43 log units) above, and the stated range covers the measured number.
By their numbers in this assay, from the lowest: compounds 3 and 2 (each within the scatter of the next); then compound 1.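

Within the data shown here, the pair gives the first direct reading of this position: in this assay, methoxy in place of dimethylamino on an aromatic carbon, para to a large group, produces a 7.4-fold lower number from compound 1 to compound 3 (0.87 log units; beyond the scatter). The position is therefore sensitive to the group it carries, even though the two groups have matching counts of hydrogen-bond donors and acceptors and neither has a net charge; what separates them in those counts is 3 heavy atoms against 2, and nitrogen against oxygen. No measurement shown here accounts for the size of this step.

A single exchange cannot show whether the heavy-atom count or the identity of the attached atom matters more, since both change together between compound 1 and compound 3. An unsubstituted amine, a hydroxyl group or a longer ethoxy chain at the same place would begin to separate these two differences and show whether the stronger inhibition of growth seen with methoxy extends to other groups.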